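The source may report more compounds than this note shows. Statements on the series, on what has been measured and on what is new or still open speak of the compounds shown alone.

In a physicochemical assay for lipophilicity, at pH 7.4 (on this read-out lower numbers stand for lower lipophilicity and higher numbers for higher lipophilicity), compound 1 `COc1ccc2[nH]c(C)c(Br)c(=O)c2c1` gives 1.62, compound 2 `Cc1[nH]c2ccc(F)cc2c(=O)c1Br` gives 1.61 and compound 3 `CCCCC#Cc1c(C)[nH]c2ccc(OC)cc2c1=O` gives 5.25, the highest of the three numbers. Compound 4 `CCCCC#Cc1c(C)[nH]c2ccc(F)cc2c1=O` is still unmeasured. Its structure departs from that of compound 3 by fluoro in place of methoxy on an aromatic carbon.

The same exchange has been measured once, as a number 0.01 log units lower from compound 1 to compound 2 (within the scatter), on a pair carrying bromo rather than hex-1-yn-1-yl. The large step, a number 3.63 log units higher from compound 1 to compound 3 (beyond the scatter), is hex-1-yn-1-yl in place of bromo on an aromatic carbon. It sets the level of compound 3, but it does not involve the methoxy group. For the measured compounds named here, no measured pair shows whether the exchange behaves alike when hex-1-yn-1-yl is present, so the range is kept wider than the single precedent alone would suggest.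

In this assay, no change beyond the scatter is expected. The estimated step is a number 0.05 log units lower from compound 3 to compound 4 (within the scatter). For compound 4 the expected value is 5.2, with an estimated range of 4.8 to 5.6.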

Compound 4, distribution coefficient: 5.64
Compound 4: the middle estimate sits 0.44 log units below what was measured, outside the stated range (above it).
By their numbers in this assay, from the lowest: compounds 2 and 1 (each within the scatter of the next); then compound 3; then compound 4.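

In this assay, fluoro in place of methoxy at this position does not behave the same in every setting: with hex-1-yn-1-yl present the change gives a number 0.39 log units higher from compound 3 to compound 4 (beyond the scatter), while with bromo present it gave a number 0.01 log units lower from compound 1 to compound 2 (within the scatter). Hex-1-yn-1-yl in place of bromo gives a large step on the fluoro pair as well, a number 4.03 log units higher from compound 2 to compound 4 (beyond the scatter), as it did on the methoxy pair, a number 3.63 log units higher from compound 1 to compound 3 (beyond the scatter). Nothing in hand explains why the exchange differs between the two settings.

From the compounds shown here alone, it remains open whether chloro or trifluoromethyl at this position would also depend on the group carried in place of hex-1-yn-1-yl. A shorter chain or a chain ending in an amine could show whether the difference is particular to hex-1-yn-1-yl.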